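Aryl substituent change on the shared core: compound 4

The source may hold more compounds than are shown below. What is called first, only, known or untested is meant among the compounds shown, and "the series" means these compounds.

Measured in a functional assay on A549 cells (Homo sapiens) for inhibition, read by MTT assay, with a stated time of 24 h; a higher number here means a weaker inhibitor, a lower number a stronger inhibitor:
compound 1 `CC1(C)[C@H]2CC[C@]1(C)N(Cc1cn(-c3ccccc3Br)nn1)C(=O)C2`: 130 nM
compound 2 `CC1(C)[C@H]2CC[C@]1(C)N(Cc1cn(-c3ccccc3C#N)nn1)C(=O)C2`: 100 nM
compound 3 `CC1(C)[C@H]2CC[C@]1(C)N(Cc1cn(-c3cccc(C#N)c3)nn1)C(=O)C2`: 440 nM

Compound 2 gives the lowest number of the three. The step of a 1.3-fold lower number from compound 1 to compound 2 (0.11 log units; within the scatter) is small, so these two cannot be ordered. Compound 3 sits clearly apart: a 4.4-fold higher number from compound 2 to compound 3 (0.64 log units; beyond the scatter), and likewise a 3.4-fold higher number from compound 1 to compound 3 (0.53 log units; beyond the scatter).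

Compound 4 `COc1cccc(-n2cc(CN3C(=O)C[C@@H]4CC[C@@]3(C)C4(C)C)nn2)c1` is derived from compound 2 by one change: 3-methoxyphenyl in place of 2-cyanophenyl on an aromatic nitrogen.

Within the data shown here, two measured steps bear on this. Both a 4.4-fold higher number from compound 2 to compound 3 (0.64 log units; beyond the scatter) and a 3.4-fold higher number from compound 1 to compound 3 (0.53 log units; beyond the scatter) move from a 2-substituted to a 3-substituted phenyl on the aromatic nitrogen, and both raise the number by a modest, beyond-scatter margin. Among the measured compounds shown here, no measured compound carries a methoxy group, so the swap of nitrile for methoxy itself has no measured counterpart; the step from 2-cyanophenyl to 2-bromophenyl, a 1.3-fold lower number from compound 1 to compound 2 (0.11 log units; within the scatter), suggests the nature of the substituent mattered less than its position here. For compound 4 a modest rise in number is therefore expected: a 4.0-fold higher number from compound 2 to compound 4 (0.60 log units; beyond the scatter). The estimate for compound 4 in this assay is 400 nM, with a range of 150 nM to 1100 nM.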

Compound 4, half-maximal inhibitory concentration: 240 nM
Compound 4: the middle estimate sits 1.7-fold (0.22 log units) above what was measured; the range from low to high includes it.
By their numbers in this assay, from the lowest: compounds 2, 1, 4 and 3 (each within the scatter of the next, the first and the last beyond it).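

In this assay, among these compounds, the two groups on the aromatic nitrogen, 3-cyanophenyl and 3-methoxyphenyl, cannot be told apart: a 1.8-fold lower number from compound 3 to compound 4 (0.26 log units; within the scatter) is the first comparison of two different groups carried as 3-substituted phenyls. Compound 4 also cannot be separated from the 2-bromophenyl compound, with a 1.8-fold higher number from compound 1 to compound 4 (0.27 log units; within the scatter), yet it does separate from the 2-cyanophenyl compound, with a 2.4-fold higher number from compound 2 to compound 4 (0.38 log units; beyond the scatter), so in this set the 3-methoxyphenyl group stands clearly apart from only one of the two 2-substituted phenyls. No measured evidence accounts for any of these steps.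

Open, as far as these compounds go, is whether an amine or a carboxylic acid on the phenyl ring would stay in the same range in this assay. Also open, from the compounds shown here alone, is whether a longer chain on the oxygen, such as ethoxy or propoxy, would keep the number of compound 4.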